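Swapping chlorines for fluorines on a chalcone-like pyrazole

The source may hold more compounds than are shown below. What is called first, only, known or untested is meant among the compounds shown, and "the series" means these compounds.

Of the compounds shown here, three have been measured in a functional assay on RPMI-8226 cells (Homo sapiens) for inhibition, read by sulforhodamine B assay, with a stated time of 48 h; on this read-out higher numbers stand for weaker inhibition of growth and lower numbers for stronger inhibition of growth. Compound 1 `COc1ccc(-c2cc(/C=C/C(=O)c3ccc(OC)c(OC)c3)[nH]n2)cc1` gives 320 nM, compound 3 `COc1ccc(-c2cc(/C=C/C(=O)c3ccc(N)cc3)[nH]n2)cc1` gives 600 nM, and compound 2 `COc1cc(-c2cc(/C=C/C(=O)c3ccc(Cl)c(Cl)c3)[nH]n2)cc(OC)c1OC` gives 530 nM. The number for compound 2 sits between the other two, and both of them lie within the usual scatter of it, so the three cannot be told apart on this read-out.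

Compound 4 `COc1cc(-c2cc(/C=C/C(=O)c3ccc(F)c(F)c3)[nH]n2)cc(OC)c1OC` differs from compound 2 in one place: 3,4-difluorophenyl in place of 3,4-dichlorophenyl on a carbonyl carbon. For the measured compounds named here, no measured pair here carries this exchange, so there is nothing to show its size. Given that the three measured values all sit close together, the step from compound 2 to compound 4 in this assay is expected to be small, a 1.3-fold higher number from compound 2 to compound 4 (0.12 log units; within the scatter), if anything a slight weakening. Compound 4 is therefore estimated at 700 nM, with a likely range from 300 nM to 1600 nM.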

Compound 4, concentration for 50% growth inhibition: 1760 nM
Compound 4: middle estimate off by 2.5-fold (0.40 log units), on the low side; the whole stated range lies below it.
By their numbers in this assay, from the lowest: compounds 1, 2 and 3 (each within the scatter of the next); then compound 4.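

Here 3,4-dichlorophenyl on a carbonyl carbon does not trade freely for 3,4-difluorophenyl: in this assay the exchange gives a 3.3-fold higher number from compound 2 to compound 4 (0.52 log units; beyond the scatter), the only step in this series so far and one beyond the scatter. This position therefore responds to a swap between two groups of equal heavy-atom count. No measurement shown here accounts for the weakening.

Open, going by these compounds, is whether the trend continues with 3,4-dibromophenyl in the same place, and how an unsubstituted phenyl compares. Also open, on these data alone, is whether the exchange has a similar effect on the core of compound 1.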